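The compounds below may be only part of what the source reports. "The series", "measured", "known", "first", "only" and "open" are said of these compounds alone.

Measured so far in an ADME assay on L6 cells (Rattus norvegicus) for cytotoxicity; on this read-out higher numbers stand for weaker inhibition and lower numbers for stronger inhibition:
compound 1, `O=C(Cn1ccnc1[N+](=O)[O-])N1CCN(c2ncccn2)CC1`: 280000 nM
compound 2, `O=C(Cn1cnc([N+](=O)[O-])n1)N1CCN(c2ncccn2)CC1`: 150000 nM
compound 3, `O=C(CN1CCN(c2ccc(Cl)cc2)CC1)N1CCN(c2ccc(Cl)cc2)CC1`: 116000 nM

Compound 2 has a number lying between those of compound 1 and compound 3, and its gaps to both fall within the usual scatter of this assay, so no ordering among the three can be claimed. Compound 4, `Cc1ccc(N2CCN(C(=O)Cn3cnc([N+](=O)[O-])n3)CC2)cc1`, has not yet been measured. It differs from compound 2 in one place: 4-methylphenyl in place of pyrimidin-2-yl on an amine nitrogen in a ring. Among the measured compounds shown here, no pair of measured compounds differing in a single place is at hand, so this change has no measured precedent here. Compound 3, which carries an aromatic ring of carbon only on each of its ring nitrogens, gives 116000 nM, a number close to that of compound 2. The step of a 1.3-fold lower number from compound 2 to compound 4 (0.10 log units; within the scatter) is therefore expected to stay within or near the scatter, if anything toward a lower number. Compound 4 is expected to give 120000 nM in this assay, within 40000 nM to 350000 nM.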

Compound 4, half-maximal inhibitory concentration: 148000 nM
The estimate for compound 4 lay 1.2-fold (0.09 log units) below the measured number, and the stated range covers the measured number.
By their numbers in this assay, from the lowest: compounds 3, 4, 2 and 1 (each within the scatter of the next, the first and the last beyond it).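

In this assay, among the compounds shown here, 4-methylphenyl in place of pyrimidin-2-yl on the amine nitrogen in the ring gives a 1.0-fold lower number from compound 2 to compound 4 (0.01 log units; within the scatter), the first comparison here of compounds that differ in one place. At this position, a six-membered aromatic ring of carbon only thus takes the place of one with 2 hetero atoms without a readable change in the number. No measurement at hand bears on the reason for this result.

On these data alone, whether a group such as a carboxylic acid or an aliphatic amine at this nitrogen would also leave the number unchanged remains open. So does whether the same exchange would behave alike on the core of compound 1.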